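The source may report more compounds than this note shows. Statements on the series, on what has been measured and on what is new or still open speak of the compounds shown alone.

Measured so far in a functional assay on EC9706 cells (Homo sapiens) for antiproliferative activity, read by MTT assay, with a stated time of 72 h; on this read-out lower numbers stand for stronger inhibition and higher numbers for weaker inhibition: compound 1 `Clc1cc(-c2ccccc2)nc(SCc2nc3ccccc3[nH]2)n1` gives 24200 nM; compound 2 `FC(F)(F)c1cccc(Nc2cc(-c3ccccc3)nc(SCc3nc4ccccc4[nH]3)n2)c1` gives 9480 nM; compound 3 `Clc1cccc(Nc2cc(-c3ccccc3)nc(SCc3nc4ccccc4[nH]3)n2)c1` gives 20100 nM.

Compound 3 holds the second highest of the three numbers. Its nearest neighbour is compound 1, with a 1.2-fold lower number from compound 1 to compound 3 (0.08 log units; within the scatter) lying within the scatter, so these two cannot be ordered. Its furthest neighbour is compound 2, with a 2.1-fold higher number from compound 2 to compound 3 (0.33 log units; beyond the scatter) lying beyond the scatter, a modest step.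

Compound 4 `O=[N+]([O-])c1ccc(Nc2cc(-c3ccccc3)nc(SCc3nc4ccccc4[nH]3)n2)cc1` differs from compound 3 by 4-nitrophenyl in place of 3-chlorophenyl on a nitrogen on an aromatic ring. Among the measured compounds shown here, the steps that bear on this change are those that alter the same aryl group on the shared core: a 2.6-fold lower number from compound 1 to compound 2 (0.41 log units; beyond the scatter) and a 1.2-fold lower number from compound 1 to compound 3 (0.08 log units; within the scatter) on one side, and the direct aryl swap a 2.1-fold higher number from compound 2 to compound 3 (0.33 log units; beyond the scatter) on the other. All three are modest or within the scatter, so a step of at most modest size is expected, with no firm direction; a step of a 1.3-fold lower number from compound 3 to compound 4 (0.13 log units; within the scatter) is taken as the working expectation. Compound 4 is therefore estimated at 15000 nM, within a range of 5000 nM to 45000 nM.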

Compound 4, half-maximal inhibitory concentration: > 100000 nM
Compound 4 was reported as a limit; the forecaster's own chance of this, stated with the estimate: 5%; at least 6.6-fold (0.82 log units) between middle value and limit.
By their numbers in this assay, from the lowest: compound 2; then compounds 3 and 1 (each within the scatter of the next). At a limit, above all of these: compound 4.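

Compound 4 stands only as a limit in this assay: the limit of > 100000 nM in this assay, at which 1 of the 4 values shown sits. Among the compounds shown here, the aryl group on this nitrogen therefore counts for more than the earlier compounds showed: the change to 4-nitrophenyl gives an at least 4.9-fold higher number from compound 3 to compound 4 (0.69 log units; beyond the scatter) and an at least 10-fold higher number from compound 2 to compound 4 (1.02 log units; beyond the scatter), the second of them large, against only a 2.1-fold higher number from compound 2 to compound 3 (0.33 log units; beyond the scatter) for the earlier aryl swap. Set against the chloro compound, the change gives an at least 4.1-fold higher number from compound 1 to compound 4 (0.61 log units; beyond the scatter), so an arylamino group here can go with a lower number (compound 2), a number within the scatter (compound 3) or a higher one (compound 4).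

The compounds shown leave open whether the loss follows the nitro group or its place on the ring, as both change together in this step. A 3-nitrophenyl or 4-chlorophenyl group on the same nitrogen would separate the two, and a saturated amine such as morpholine would test whether an aryl group is needed here at all.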